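From 3-hydroxypropyl to 2-methoxyethyl on a shared core

The source may hold more compounds than are shown below. What is called first, only, known or untested is meant among the compounds shown, and "the series" means these compounds.

Measured in a functional assay (trachea) with Cavia porcellus as the target; on this read-out higher numbers stand for an effect only at larger amounts of compound and lower numbers for an effect already at smaller amounts:
- compound 1 `CCCn1c(=O)n(CC)c(=O)c2[nH]cnc21`: 1300 nM
- compound 2 `CCCn1c(=O)n(CCC(=O)O)c(=O)c2[nH]cnc21`: 21200 nM
- compound 3 `CCCn1c(=O)n(CCCO)c(=O)c2[nH]cnc21`: 5100 nM

Compound 3 stands in the middle of these three numbers. The steps that place it there are a 3.9-fold higher number from compound 1 to compound 3 (0.59 log units; beyond the scatter) and a 4.2-fold lower number from compound 2 to compound 3 (0.62 log units; beyond the scatter).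

The next compound, compound 4 `CCCn1c(=O)n(CCOC)c(=O)c2[nH]cnc21`, has not yet been measured in this assay. It holds the same atoms as compound 3, joined differently: methoxy in place of hydroxymethyl on a saturated chain carbon, two bonds along the chain from an aromatic nitrogen. In words, this is methoxy in place of hydroxymethyl on a saturated chain carbon, two bonds along the chain from an aromatic nitrogen.

Two measured steps at this place bear on the question. Hydroxymethyl in place of hydrogen gave the modest 3.9-fold higher number from compound 1 to compound 3 (0.59 log units; beyond the scatter), and carboxy in place of hydrogen gave the large 16-fold higher number from compound 1 to compound 2 (1.21 log units; beyond the scatter). Neither step tests methoxy, so the evidence is thin. Both steps raised the number from compound 1, which has the lowest value at 1300 nM. A modest move back towards compound 1 seems the most reasonable guess, though a result within the scatter would be no surprise.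

The expected change is a 2.0-fold lower number from compound 3 to compound 4 (0.29 log units; within the scatter). For compound 4 the estimated value is 2600 nM, with an expected range from 1100 nM to 6000 nM.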

Compound 4, half-maximal effective concentration: 700 nM
Beside the measured number, compound 4's estimate is 3.7-fold (0.57 log units) above it; the measured number lies below the stated range.
By their numbers in this assay, from the lowest: compounds 4 and 1 (each within the scatter of the next); then compound 3; then compound 2.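

Compound 3 and compound 4 hold the same atoms, so this position responds to how those atoms are joined and not only to which atoms are present: in this assay, going from 3-hydroxypropyl to 2-methoxyethyl, a change from 1 hydrogen-bond donor to 0 hydrogen-bond donors in the group at the chain end, gives a 7.3-fold lower number from compound 3 to compound 4 (0.86 log units; beyond the scatter). Until now, both changes made to this chain had raised the number, but the methoxy group does not repeat that, since the result is a 1.9-fold lower number from compound 1 to compound 4 (0.27 log units; within the scatter), which leaves compound 1 and compound 4 indistinguishable in this test. The carboxy and methoxy groups are also far apart at this place, with a 30-fold lower number from compound 2 to compound 4 (1.48 log units; beyond the scatter), the widest gap among the compounds shown.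

Nothing available here explains why the methoxy and hydroxymethyl groups differ so much at this position. As far as these compounds go, it remains open whether this tolerance extends to an ethoxy group in place of the methoxy, to an amine at the chain end, or to a longer chain that still ends in methoxy.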